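Sulfone series: clearance notes for compound 4

This account rests on a few compounds, and the source may have more. Where it says the series, first, only, none or still open, it means among the compounds named here.

Measured compounds:
compound 1 `O=S(=O)(c1ccc(F)c(F)c1)c1cnc2cc(F)ccc2c1-c1ccc(Cl)cc1`: 0.01 mL/min
compound 2 `O=S(=O)(c1ccc(F)c(F)c1)c1cnc2cc(F)ccc2c1-c1cccc(Cl)c1`: 0.38 mL/min
compound 3 `O=S(=O)(c1ccc(F)c(Cl)c1)c1cnc2cc(F)ccc2c1-c1ccccc1F`: 1.07 mL/min

In an ADME assay on microsomes from liver (Homo sapiens) for metabolic stability, tested at 2.5 uM (on this read-out lower numbers stand for slow clearance and higher numbers for fast clearance), compound 3 gives 1.07 mL/min, the highest of the three numbers; compound 2 is nearest and compound 1 furthest, both gaps beyond the scatter. Compound 4 `O=S(=O)(c1ccc(F)c(F)c1)c1cnc2cc(F)ccc2c1-c1ccccc1F` differs from compound 3 by fluoro in place of chloro on an aromatic carbon. Going by the values given here, the only measured step, a 38-fold higher number from compound 1 to compound 2 (1.58 log units; beyond the scatter), concerns the chlorophenyl on the core, not the sulfonyl aryl, so it does not bear on this change directly. Compound 4 shares the 3,4-difluorophenyl sulfone of compounds 1 and 2, whose values sit well below compound 3, but their other aryl differs too. For compound 4 a step no larger than the scatter, leaning lower, is expected: a 1.5-fold lower number from compound 3 to compound 4 (0.18 log units; within the scatter). Compound 4 is thus estimated at 0.7 mL/min, within 0.25 mL/min to 2 mL/min.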

Compound 4, intrinsic clearance in a liver preparation (reported as CLH), per the amount of preparation that the assay uses: 0.79 mL/min
Compound 4: the middle estimate sits 1.1-fold (0.05 log units) below what was measured; measured number inside the range.
By their numbers in this assay, from the lowest: compound 1; then compound 2; then compounds 4 and 3 (each within the scatter of the next).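

In this assay fluoro in place of chloro on this sulfonyl aryl carbon leaves the number within the scatter (a 1.4-fold lower number from compound 3 to compound 4 (0.13 log units; within the scatter)), so 3-chloro-4-fluorophenyl and 3,4-difluorophenyl are not told apart here. With the 3,4-difluorophenyl sulfone held constant, the chlorophenyl-to-2-fluorophenyl changes on the core do exceed the scatter, modestly in one case (a 2.1-fold higher number from compound 2 to compound 4 (0.32 log units; beyond the scatter)) and largely in the other (a 79-fold higher number from compound 1 to compound 4 (1.90 log units; beyond the scatter)). Nothing measured here explains these differences.

Still open, as far as these compounds go, is whether a larger replacement at the sulfonyl aryl position, such as methoxy, nitrile or an amine, would shift clearance beyond the scatter. Also open, from the compounds shown here alone, is whether the near-identity of chloro and fluoro holds with a 3-chlorophenyl or 4-chlorophenyl on the core.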